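The source may hold more compounds than are shown below. What is called first, only, known or untested is meant among the compounds shown, and "the series" means these compounds.

Measured compounds:
- Compound 1 `COc1cc(/C=C/C(=O)c2cccc(-n3cc(-c4ccccc4)[nH]c3=O)c2)cc(OC)c1OC` gives 4120 nM in a functional assay on HOP-62 cells (Homo sapiens) for inhibition; a lower number here means a stronger inhibitor of growth, a higher number a weaker inhibitor of growth.
- Compound 2 `O=C(/C=C/c1cccc(O)c1)c1cccc(-n2cc(-c3ccccc3)[nH]c2=O)c1` gives 6930 nM in this assay.

For the measured compounds named here, compound 1 has the lowest of the two numbers so far, but its gap to compound 2 lies within the usual scatter, so the two cannot be told apart on these data.

Compound 3 `COc1cc(/C=C/C(=O)c2cccc(-n3cc(-c4cc(OC)c(OC)c(OC)c4)[nH]c3=O)c2)cc(OC)c1OC` has not been measured yet. It differs from compound 1 in one place: 3,4,5-trimethoxyphenyl in place of phenyl on an aromatic carbon. Going by the values given here, no measured pair in this set shows what such a change does, so there is no step to lean on. The expectation for compound 3 therefore rests on compound 1 alone, with its 4120 nM, and the change is expected to move the number little, if at all, beyond the scatter in either direction. The step from compound 1 to compound 3 is estimated at a 1.4-fold lower number from compound 1 to compound 3 (0.14 log units; within the scatter). Compound 3 is thus expected at about 3000 nM, with a range from 800 nM to 12000 nM.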

Compound 3, concentration for 50% growth inhibition: 3080 nM
Estimate against measurement, compound 3: 1.0-fold (0.01 log units) below; the range from low to high includes it.
By their numbers in this assay, from the lowest: compounds 3, 1 and 2 (each within the scatter of the next, the first and the last beyond it).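

Placing 3,4,5-trimethoxyphenyl in place of phenyl on the aromatic carbon next to the ring nitrogen gives a 1.3-fold lower number from compound 1 to compound 3 (0.13 log units; within the scatter) in this assay. This position of the shared core therefore carries a group of 12 heavy atoms instead of 6, including 3 hydrogen-bond acceptors, with no shift in growth inhibition that can be told apart from the scatter. Nothing measured here points to a cause for this result.

Going by these compounds, it remains open whether an amine or a carboxylic acid on this carbon would move the number beyond the scatter, and whether a small group such as methyl would do so. On these data alone, it is also open whether a phenyl ring bearing a single methoxy group would behave like either compound 1 or compound 3.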